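The compounds below may be only part of what the source reports. "The series", "measured", "known", "first", "only" and "open" are said of these compounds alone.

Cell-toxicity testing asks whether a compound harms the cells it is placed on. In an ADME assay on MT4 cells (Homo sapiens) for cytotoxicity, read by MTT assay, with a stated time of 96 h (on this read-out lower numbers stand for higher toxicity in this test and higher numbers for lower toxicity in this test), compound 2 (`O=c1ccc2ccc(O)c(CN3CCc4ccccc4C3)c2o1`) gives > 100000 nM as its result, and this is a limit of the assay, not a number. Compound 1 (`CCCOc1ccc2c(C)cc(=O)oc2c1CN1CCc2ccccc2C1`) gives > 100000 nM as its result, again a limit and not a number. Compound 2 therefore has no exact place on the scale: the whole measured picture is the limit of > 100000 nM in this assay, at which 2 of the 2 values shown sit, and nothing finer can be said of it.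

Compound 3 (`CCCOc1ccc2ccc(=O)oc2c1CN1CCc2ccccc2C1`) differs from compound 2 in one place, with propyl in place of hydrogen on an oxygen on an aromatic ring, that is, hydroxy to propoxy (propyl in place of hydrogen on an oxygen on an aromatic ring). Among the measured compounds shown here, no measured step between two compounds is available as a guide. In this assay no step beyond the usual scatter is expected, in either direction, and the result may well be a limit again. The expected size of the change is a number no higher from compound 2 to compound 3 (the limit leaves the size open) on this estimate. Compound 3 is expected near 100000 nM in this assay, with an estimated range from 40000 nM to 200000 nM for its result.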

Compound 3, half-maximal cytotoxic concentration: 11000 nM
Estimate against measurement, compound 3: 9.1-fold (0.96 log units) above; the whole stated range lies above it.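

In this assay, the oxygen on the aromatic ring proves to be a place where a change can be seen, which the two limits alone could not show: going from hydroxy to propoxy gives an at least 9.0-fold lower number from compound 2 to compound 3 (0.95 log units; beyond the scatter), and a lower number here stands for higher toxicity to the cells. Propoxy alone does not settle the outcome, since compound 1 also carries propoxy yet differs by a methyl on an aromatic carbon, and hydrogen in place of that methyl gives an at least 9.0-fold lower number from compound 1 to compound 3 (0.95 log units; beyond the scatter), so in this small set the toxicity appears only where propoxy is present and that methyl is absent. Only compound 3 has an exact place on the scale, which means both steps give a smallest possible size and not a true one: the limit of > 100000 nM in this assay, at which 2 of the 3 values shown sit.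

The compounds shown leave open whether the length of the chain on that oxygen matters, since neither a shorter methyl ether nor a longer butyl chain stands among them. They also leave open whether an amine or a carboxylic acid at the end of the propyl chain would keep the number near that of compound 3 or return it to the limit.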